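Swapping an anilino group for pyrrolidinyl on a shared core

The source may hold more compounds than are shown below. What is called first, only, known or untested is meant among the compounds shown, and "the series" means these compounds.

Measured compounds:
- compound 1, `O=C1C(Nc2ccccc2F)=CC(=O)c2c1nc1n2[C@H]2OC[C@@H](O)[C@H]2OC1`, 9820 nM
- compound 2, `O=C1C(Nc2ccc(Br)cc2)=CC(=O)c2c1nc1n2[C@H]2OC[C@@H](O)[C@H]2OC1`, 5220 nM
- compound 3, `O=C1C=C(Nc2cccc(F)c2)C(=O)c2c1nc1n2[C@H]2OC[C@@H](O)[C@H]2OC1`, 6440 nM

All three were tested in a functional assay on HeLa cells (Homo sapiens) for inhibition, read by sulforhodamine B assay; on this read-out higher numbers stand for weaker inhibition and lower numbers for stronger inhibition. Compound 3 sits close to both companions: its number is nearest that of compound 2 and not far from that of compound 1, both gaps within the scatter, so no ranking among the three can be claimed.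

Compound 4, `O=C1C=C(N2CCCC2)C(=O)c2c1nc1n2[C@H]2OC[C@@H](O)[C@H]2OC1`, is not yet measured. It differs from compound 3 in one place: pyrrolidin-1-yl in place of (3-fluorophenyl)amino on a double-bonded ring carbon. Among the compounds with values here, the only measured step, a 1.9-fold lower number from compound 1 to compound 2 (0.27 log units; within the scatter), changes one aryl group for another on an amine nitrogen and stays within the scatter; it does not bear directly on replacing an anilino group by a saturated ring. There is thus no measured guide for this change, and the expectation for compound 4 is a number near that of compound 3, with a wide range because the change is of a different kind, giving an expected step of a 1.1-fold higher number from compound 3 to compound 4 (0.04 log units; within the scatter). Compound 4 is estimated at 7000 nM, between 2000 nM and 25000 nM.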

Compound 4, half-maximal inhibitory concentration: > 16000 nM
Compound 4: only a limit was reported (the forecaster's own chance of this, stated with the estimate: 15%); at least 2.2-fold (0.35 log units) between middle value and limit.
By their numbers in this assay, from the lowest: compounds 2, 3 and 1 (each within the scatter of the next). At a limit, above all of these: compound 4.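

Replacing (3-fluorophenyl)amino with pyrrolidin-1-yl on this double-bonded ring carbon is the first change among these compounds to go beyond the scatter in this assay: an at least 2.4-fold higher number from compound 3 to compound 4 (0.39 log units; beyond the scatter). Here a higher number stands for weaker inhibition, so this position does not tolerate every group equally, and the five-membered non-aromatic ring goes with weaker inhibition than the anilino group it replaces. The result for compound 4 is a limit, not a number: the limit of > 16000 nM in this assay, at which 1 of the 4 values shown sits.

This single change removes the aromatic ring and the amine hydrogen together, so the compounds shown cannot tell which of the two matters. A methyl(phenyl)amino group would keep the aromatic ring without that hydrogen, while a cyclohexylamino group would keep the hydrogen without the aromatic ring, and these two could pull the effects apart.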